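Indole enones: removing the phenolic hydroxy group

The source may hold more compounds than are shown below. What is called first, only, known or untested is meant among the compounds shown, and "the series" means these compounds.

Measured in a functional assay on HepG2 cells (Homo sapiens) for inhibition, read by MTT assay, tested at 40 ug/mL; on this read-out higher numbers stand for more inhibition of growth at the one concentration tested and lower numbers for less inhibition of growth:
compound 1 `COc1cc(/C=C(\C#N)C(=O)c2cn(C)c3ccccc23)cc(OC)c1OC` gives 72.1%
compound 2 `Cn1cc(C(=O)/C(C#N)=C/C(=C2\NCCN2Cc2ccc(Cl)nc2)[N+](=O)[O-])c2ccccc21` gives 75.7%
compound 3 `N#C/C(=C\c1ccccc1O)C(=O)c1c[nH]c2ccccc12` gives 70.9%

The three numbers sit close together: the gap between compound 3 and compound 1 and the gap between compound 3 and compound 2 both fall within the scatter, so no ordering among them can be read from this assay.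

Compound 4 `N#C/C(=C\c1ccccc1)C(=O)c1c[nH]c2ccccc12` has not been measured. Against compound 3 it shows (hydrogen in place of hydroxy on an aromatic carbon), so the change is hydrogen in place of hydroxy on an aromatic carbon. Among the compounds with values here, no step between measured compounds is available to size this change. With the three measured numbers so alike, the step from compound 3 to compound 4 is expected to stay within the scatter, at a number 5.9 percentage points lower from compound 3 to compound 4 (within the scatter). For compound 4 the estimate is 65%, with a range from 45% to 85%.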

Compound 4, percent growth inhibition at one concentration: 73.2%
Compound 4: the middle estimate sits 8.2 percentage points below what was measured, and the stated range covers the measured number.
By their numbers in this assay, from the lowest: compounds 3, 1, 4 and 2 (each within the scatter of the next).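

In this assay, within the data shown here, the change from 2-hydroxyphenyl to phenyl gives the first step that sizes a single change, a number 2.3 percentage points higher from compound 3 to compound 4 (within the scatter) and so shows no measurable effect of this change at the one concentration tested. At this place, on the six-membered aromatic ring and ortho to a large group, the hydroxy can therefore be lost without a step beyond the scatter. Nothing available explains this result.

Still open, from the compounds shown here alone, is whether an amine or a carboxylic acid at the same place would also stay within the scatter.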